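Ring Size Change on the Shared Core: Compound 3 to Compound 4

A few compounds are considered here, and "the series" means these few. Any claim that something is new, unique, unknown or untested is made for them only; others in the source may bear on it.

Measured so far, in an assay on HeLa cells for inhibition of sphingosine-1-phosphate transporter SPNS2 (Mus musculus), read by LC-MS, tested at 2 uM; a higher number here means more inhibition at the concentration tested (going by the name of the read-out), a lower number less inhibition:
Compound 1 `CCCCCCCCCCc1ccc(-c2noc(C3CNC3)n2)cc1` gives 65%
Compound 2 `CCCCCCCCCCc1ccc(-c2noc(CCCCN)n2)cc1` gives 55%
Compound 3 `CCCCCCCCCCc1ccc(-c2noc(CC3CNC3)n2)cc1` gives 63%

Compound 3 stands second highest of these three, and its two steps to the others, a number 2 percentage points lower from compound 1 to compound 3 (within the scatter) and a number 8 percentage points higher from compound 2 to compound 3 (within the scatter), both lie within the scatter. Compound 4 `CCCCCCCCCCc1ccc(-c2noc([C@@H]3CCCN3)n2)cc1` differs from compound 3 by pyrrolidin-2-yl in place of (azetidin-3-yl)methyl on an aromatic carbon. Among the compounds with values here, no measured step swaps a four-membered ring for a five-membered one, so the comparison rests on the two steps above, which also rearranged the amine-bearing group without a step beyond the scatter. The expected change is therefore a number 3 percentage points lower from compound 3 to compound 4 (within the scatter), none beyond the scatter. Compound 4 is estimated at 60%, expected between 45% and 75%.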

Compound 4, a percentage reported as inhibition, at one concentration (the size of the read-out at that concentration, not a potency): 21%
Compound 4: the middle estimate sits 39 percentage points above what was measured; measured number outside the range, below it.
By their numbers in this assay, from the lowest: compound 4; then compounds 2, 3 and 1 (each within the scatter of the next).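

At this position on the five-membered aromatic ring, the three earlier amine-bearing groups stayed within the scatter of one another in this assay, but pyrrolidin-2-yl does not join them: a number 42 percentage points lower from compound 3 to compound 4 (beyond the scatter), a number 34 percentage points lower from compound 2 to compound 4 (beyond the scatter) and a number 44 percentage points lower from compound 1 to compound 4 (beyond the scatter). Compound 3 and compound 4 have the same atoms joined differently, so the arrangement of those atoms matters here, not just their presence. Nothing available explains this drop. The compounds shown leave open whether it belongs to the five-membered ring itself or to how that ring is attached, which pyrrolidin-3-yl would help separate. The other stereoisomer of pyrrolidin-2-yl is also an open case.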